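Geometry swap at the exocyclic double bond of compound 2

The source may report more compounds than this note shows. Statements on the series, on what has been measured and on what is new or still open speak of the compounds shown alone.

Measured so far in an assay for displacement of a labelled ligand from protein kinase C delta type (Mus musculus), with a stated time of 30 min, in the presence of a further agent that is not named here; on this read-out higher numbers stand for weaker binding and lower numbers for tighter binding:
compound 1, `CC(C)CC(CC(=O)OCC1(CO)C/C(=C\c2cccc(C(C(=O)OC(C)(C)C)C(=O)OC(C)(C)C)c2)C(=O)O1)CC(C)C`: 0.5 nM
compound 2, `CC(C)C(CC(=O)OCC1(CO)C/C(=C/c2ccc(C(=O)O)cc2)C(=O)O1)C(C)C`: 865 nM
compound 3, `CC(C)CC(CC(=O)OCC1(CO)C/C(=C\c2ccc(C(C(=O)OC(C)(C)C)C(=O)OC(C)(C)C)cc2)C(=O)O1)CC(C)C`: 0.6 nM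

Compound 2 stands at the top of the three numbers in this assay, a long way from both of the others. Its nearest neighbour on the numbers is compound 3, and compound 1 lies a little further still; both of these carry the bis-tert-butyl ester side arm and a longer branched ester chain where compound 2 carries a free carboxylic acid and a shorter branched chain, so neither pair offers a one-point step and no cause for the gap can be assigned from what is in hand.

The unmeasured compound 4, `CC(C)C(CC(=O)OCC1(CO)C/C(=C\c2ccc(C(=O)O)cc2)C(=O)O1)C(C)C`, keeps every atom and bond of compound 2. (the two compounds have the same atoms and bonds; at least one stereo element is drawn with a configuration in one of them and without one in the other: 1 of 2 stereo elements differ; a double bond is drawn Z in compound 2 and E in compound 4). Within the data shown here, no measured pair in the set isolates this change, so the expected step in this assay is set at no movement beyond the scatter, in either direction. The estimate for compound 4 in this assay is therefore 800 nM, with a range of 150 nM to 4000 nM, which corresponds to an expected step of a 1.1-fold lower number from compound 2 to compound 4 (0.03 log units; within the scatter).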

Compound 4, dissociation constant: 560 nM
Beside the measured number, compound 4's estimate is 1.4-fold (0.15 log units) above it; the measured number falls inside the stated range.
By their numbers in this assay, from the lowest: compounds 1 and 3 (each within the scatter of the next); then compounds 4 and 2 (each within the scatter of the next).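

In this assay, the series now has its first pair differing in one place, and the swap at the exocyclic double bond amounts to a 1.5-fold lower number from compound 2 to compound 4 (0.19 log units; within the scatter). With the free carboxylic acid and the shorter branched chain held constant, this pair gives no sign that the geometry of the double bond moves the number beyond the scatter, and no order can be set between the two compounds. This reading rests on one fact about how the structures are drawn: the fact that one of compounds 2 and 4 is drawn with a defined configuration and the other without, at the place where they differ

Among these compounds, it remains open whether the same swap would stay this small on a compound carrying the bis-tert-butyl ester side arm and the longer branched ester chain, and compounds 1 and 3 offer no pair that tests this. Also open, going by these compounds, is which of the places separating compound 4 from compounds 1 and 3 governs the number in this assay, including whether a methyl ester or a primary amide in place of the carboxylic acid, with the shorter branched chain retained, would shift it.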